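The source may hold more compounds than are shown below. What is called first, only, known or untested is meant among the compounds shown, and "the series" means these compounds.

Measured in an ADME assay on microsomes from liver (Rattus norvegicus) for metabolic stability; on this read-out lower numbers stand for a shorter-lived compound and higher numbers for a longer-lived compound:
- compound 1 `CC(C)C(CC1C(=O)NC(=O)N1C)c1ccc(-c2ccc3cccc(F)c3c2)[nH]c1=O`: < 0.0667 h (a limit of the assay, not a number)
- compound 2 `CC(C)C(c1ccc(-c2ccc3cccc(F)c3c2)[nH]c1=O)C1NC(=O)NC1=O`: 0.145 h
- compound 3 `CC(C)C(/C=C1\SC(=O)NC1=O)c1ccc(-c2ccc3cccc(F)c3c2)[nH]c1=O`: 2.62 h

Compound 3 is the longest-lived of this set. Of the two true numbers it holds the higher, and the gap is large: an 18-fold higher number from compound 2 to compound 3 (1.26 log units; beyond the scatter). Its lead over the limit of compound 1 is also large: an at least 39-fold higher number from compound 1 to compound 3 (1.59 log units; beyond the scatter).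

The next compound, compound 4 `CC(C)C(c1ccc(-c2ccc3cccc(F)c3c2)[nH]c1=O)C1C(=O)NC(=O)N1C`, is still unmeasured. It keeps the shared core and changes one group: a group of 8 heavy atoms (4 carbon, 2 nitrogen, 2 oxygen; one five-membered non-aromatic ring with 2 hetero atoms) in place of a group of 8 heavy atoms (4 carbon, 1 nitrogen, 2 oxygen, 1 sulfur; one five-membered non-aromatic ring with 2 hetero atoms), on a saturated chain carbon bound to an aromatic carbon and a saturated chain carbon. The entering 3-methyl-2,5-dioxoimidazolidin-4-yl shares its ring name with the 2,5-dioxoimidazolidin-4-yl of compound 2 and with the group on compound 1, which also carries the 3-methyl. Those two compounds are therefore the best guides, and read in reverse, the two large steps above point downward. Among them, the change an at least 2.1-fold higher number from compound 1 to compound 2 (0.33 log units; beyond the scatter) is much smaller.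

A large drop is therefore expected in this assay, towards the level of compound 2 at 0.145 h. The expected change is a 26-fold lower number from compound 3 to compound 4 (1.42 log units; beyond the scatter). A reading that gives only a limit is a real possibility, given (the limit of < 0.0667 h in this assay, at which 1 of the 3 values shown sits). The estimate for compound 4 is 0.1 h, with an expected range of 0.04 h to 0.35 h.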

Compound 4, half-life: 0.263 h
Beside the measured number, compound 4's estimate is 2.6-fold (0.42 log units) below it; measured number inside the range.
By their numbers in this assay, from the lowest: compounds 2 and 4 (each within the scatter of the next); then compound 3. At a limit, below all of these: compound 1.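

In this assay, replacing the sulfur-containing ring group of compound 3 with 3-methyl-2,5-dioxoimidazolidin-4-yl gives a 10-fold lower number from compound 3 to compound 4 (1.00 log units; beyond the scatter), so a group with the same count of heavy atoms at this position does not keep the long half-life. Methyl in place of hydrogen on an amide-type nitrogen in a ring gives a 1.8-fold higher number from compound 2 to compound 4 (0.26 log units; within the scatter), so this pair is separated by no more than repeat measurements would be expected to show. Attaching the ring as 3-methyl-2,5-dioxoimidazolidin-4-yl in place of (3-methyl-2,5-dioxoimidazolidin-4-yl)methyl gives an at least 3.9-fold higher number from compound 1 to compound 4 (0.59 log units; beyond the scatter), and the full size of this step stays unknown, as it starts from a limit of the assay and not from a number: the limit of < 0.0667 h in this assay, at which 1 of the 4 values shown sits.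

The compounds shown leave open which feature of the group in compound 3 goes with its higher number, as the sulfur and the extra double bond outside aromatic rings change together in the step to compound 4. They also leave open how a carboxylic acid or an amine on this saturated chain carbon would compare with these ring groups.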